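Swapping a Methoxyphenyl for a Dichlorophenyl: Expected Cytotoxicity

The compounds below may be only part of what the source reports. "The series", "measured", "known", "first", "only" and "open" are said of these compounds alone.

Compound 1: `O=C(CSc1c[nH]c2c(Br)cccc12)N(Cc1ccccc1)Cc1ccccc1`, > 100000 nM
Compound 2: `COc1ccccc1CNC(=O)CSc1c[nH]c2c(Br)cccc12`, 72400 nM

In an ADME assay on HEK-293T cells (Homo sapiens) for cytotoxicity, read by CCK-8 assay, with a stated time of 24 h (a higher number here means that more compound is tolerated, a lower number that less compound is tolerated), compound 1 reaches only a limit of the assay, > 100000 nM. Compound 2 gives 72400 nM, the only actual number shown. The other value shown, that of compound 1, is a limit (the limit of > 100000 nM in this assay, at which 1 of the 2 values shown sits). Compound 3 is `O=C(CSc1c[nH]c2c(Br)cccc12)NCc1ccc(Cl)c(Cl)c1`. It differs from compound 2 by 3,4-dichlorophenyl in place of 2-methoxyphenyl on a saturated chain carbon bound to an amide-type nitrogen. Among the compounds with values here, with no measured step between the two to lean on, a change of modest size is expected, a 1.8-fold lower number from compound 2 to compound 3 (0.26 log units; within the scatter), toward less tolerated. Compound 3 is therefore estimated at 40000 nM, likely between 15000 nM and 100000 nM.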

Compound 3, half-maximal cytotoxic concentration: > 100000 nM
Compound 3: only a limit was reported; the forecaster's own chance of this, stated with the estimate: 25%; middle value at least 2.5-fold (0.39 log units) from the limit.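

In this assay, compound 3 reaches only a limit, > 100000 nM. Putting 3,4-dichlorophenyl in place of 2-methoxyphenyl on this saturated chain carbon bound to an amide-type nitrogen gives an at least 1.3-fold higher number from compound 2 to compound 3 (0.14 log units; that floor lies within the scatter), so the change shows no sign of lowering the number the way a modest drop would. The true size of the step cannot be read past that floor because the value is a limit: the limit of > 100000 nM in this assay, at which 2 of the 3 values shown sit.

Still open, from the compounds shown here alone, is whether an amine or a carboxylic acid at this place would give a number clearly different from compound 2.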